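The compounds below may be only part of what the source reports. "The series", "measured", "known", "first", "only" and "open" are said of these compounds alone.

This series is built around two aromatic rings joined through a single saturated carbon that also carries a short chain. Compound 1 `COc1ccc(C(c2ccc(OC)c(OC)c2)[C@@H](C)[C@H](C)CO)cc1OC` and compound 3 `COc1ccc(C(c2ccc(OC)c(OC)c2)[C@@H](C)[C@@H](C)CO)cc1OC` share the same atoms and bonds and differ only in the configuration drawn at one chain carbon. In a functional assay on HL-60 cells (Homo sapiens) for cytotoxicity, read by WST assay, with a stated time of 48 h (on this read-out lower numbers stand for stronger inhibition and higher numbers for weaker inhibition), compound 1 gives > 100000 nM, a limit of the assay rather than a number. Compound 3 gives > 100000 nM, also a limit. The step that the two limits leave unreadable from compound 1 to compound 3 therefore cannot be read. Among the measured compounds shown here, compound 2 `COC[C@H](C)[C@@H](C)C(c1ccc(O)c(OC)c1)c1ccc(O)c(OC)c1` is the only member with a number: in this assay compound 2 gives 68000 nM.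

Compound 4 `COc1cc(C(c2ccc(O)c(OC)c2)[C@H](CC(C)C)C(C)C)ccc1O` differs from compound 2 in one place: 1-isopropyl-3-methylbutyl in place of 2-(methoxymethyl)-1-methylpropyl on a saturated chain carbon bound to two aromatic carbons. For the measured compounds named here, no measured step bears on this change; the only step drawn, between compounds 1 and 3, concerns configuration and has no readable size. The expectation for compound 4 therefore rests on compound 2 alone, and the step of a 1.4-fold lower number from compound 2 to compound 4 (0.13 log units; within the scatter) is estimated to be small, with no direction expected beyond the scatter. Compound 4 is expected at 50000 nM, within 15000 nM to 150000 nM.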

Compound 4, half-maximal inhibitory concentration: 9600 nM
For compound 4 the middle estimate is 5.2-fold (0.72 log units) above the measured one, and the stated range ends above it.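

In this assay, among the compounds shown here, 1-isopropyl-3-methylbutyl in place of 2-(methoxymethyl)-1-methylpropyl gives a 7.1-fold lower number from compound 2 to compound 4 (0.85 log units; beyond the scatter), the first step of readable size. It shows that the number responds to the chain on the saturated chain carbon bound to two aromatic carbons, and here an all-carbon chain goes with the lower number. The earlier pair could show no such size, since compounds 1 and 3 each stand at a limit of the assay rather than at a number: the limit of > 100000 nM in this assay, at which 2 of the 4 values shown sit.

This single swap removes the oxygen and alters the chain's shape and its stereocentres together, so the compounds shown do not separate these changes. On these data alone, how an amine or a carboxylic acid on this chain would read also remains open.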